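Aryl group exchange at one carbon of the shared core

A few compounds are considered here, and "the series" means these few. Any claim that something is new, unique, unknown or untested is made for them only; others in the source may bear on it.

Compound 1 `N#Cc1ccc(F)cc1Cn1c(N2CCC[C@@H](N)C2)nc2c(F)c[nH]c2c1=O`: 0.838 h
Compound 2 `N#Cc1ccc(F)cc1Cn1c(N2CCC[C@@H](N)C2)nc2c(-c3ccc(S(N)(=O)=O)cc3)c[nH]c2c1=O`: > 3.33 h

In an ADME assay on microsomes from liver (Rattus norvegicus) for metabolic stability, read by LC-MS, tested at 1 mM (on this read-out lower numbers stand for a shorter-lived compound and higher numbers for a longer-lived compound), compound 2 stands only at a limit, > 3.33 h. Compound 3 `CS(=O)(=O)c1ccc(-c2c[nH]c3c(=O)n(Cc4cc(F)ccc4C#N)c(N4CCC[C@@H](N)C4)nc23)cc1F` differs from it on an aromatic carbon of a five-membered aromatic ring: 3-fluoro-4-(methylsulfonyl)phenyl in place of 4-sulfamoylphenyl on an aromatic carbon. Among the compounds with values here, one measured step bears on this place: an at least 3.9-fold higher number from compound 1 to compound 2 (0.59 log units; beyond the scatter), ending at a limit (the limit of > 3.33 h in this assay, at which 1 of the 2 values shown sits). Compound 2 and compound 3 both carry a six-membered aromatic ring of carbon only there, so no change beyond the scatter is expected. The estimated step is an at least 1.1-fold lower number from compound 2 to compound 3 (0.04 log units; that floor lies within the scatter). For compound 3 the expected half-life is 3 h, with an estimated range of 1.3 h to 6.5 h.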

Compound 3, half-life: 2.78 h
The estimate for compound 3 lay 1.1-fold (0.03 log units) above the measured number; the measured number falls inside the stated range.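

In this assay, within the data shown here, the change from fluoro to 3-fluoro-4-(methylsulfonyl)phenyl gives a 3.3-fold higher number from compound 1 to compound 3 (0.52 log units; beyond the scatter), the first step at this position with a measured number at both ends. The exchange of 4-sulfamoylphenyl for 3-fluoro-4-(methylsulfonyl)phenyl gives an at least 1.1-fold lower number from compound 2 to compound 3 (0.07 log units; that floor lies within the scatter), so only a floor can be read. Compound 2 stands at a limit of the assay: the limit of > 3.33 h in this assay, at which 1 of the 3 values shown sits.

Still open, on these data alone, is whether a plain phenyl, or a phenyl carrying an amine or a carboxylic acid, gives a comparable half-life. As far as these compounds go, the separate contribution of the fluoro on the phenyl of compound 3 also remains open.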